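A few compounds are considered here, and "the series" means these few. Any claim that something is new, unique, unknown or untested is made for them only; others in the source may bear on it.

Measured so far:

Compound 1, `Cc1ccnc(/C(N)=N/NC(=S)N2CCSCC2)c1`: 74.5%
Compound 2, `N/C(=N\NC(=S)N1CCSCC1)c1ccccn1`: 83.9%
Compound 3, `Cc1ccnc(/C(N)=N/NC(=S)N2CCCCCC2)c1`: 70.6%

In a functional assay on A-375 cells (Homo sapiens) for cytotoxicity, read by MTT assay, with a stated time of 72 h, tested at 10 uM (a higher number here means more inhibition of growth at the concentration tested, a lower number less inhibition of growth), compound 2 gives the highest of the three numbers, yet compound 1 lies within the scatter of it, and only compound 3 sits beyond the scatter below it. Among the measured compounds shown here, the one step with a single change, a number 9.4 percentage points higher from compound 1 to compound 2 (within the scatter), concerns the aromatic methyl and says nothing about the amine ring on the thiocarbonyl carbon. Compound 1 and compound 3 differ in that ring, and their values lie close to each other: compound 1 gives 74.5%, and compound 3 gives 70.6%.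

Compound 4, `N/C(=N\NC(=S)N1CCCC1)c1ccccn1`, differs from compound 2 in one place: pyrrolidin-1-yl in place of thiomorpholin-4-yl on a thiocarbonyl carbon. For the measured compounds named here, no measured step bears on this change, so no shift beyond the scatter is expected in this assay, with a slight lean downward given how compound 1 and compound 3 compare. Compound 4 is therefore estimated at 75%, between 55% and 90%, an expected step of a number 8.9 percentage points lower from compound 2 to compound 4 (within the scatter).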

Compound 4, percent growth inhibition at one concentration: 83.9%
For compound 4 the middle estimate is 8.9 percentage points below the measured one; measured number inside the range.
By their numbers in this assay, from the lowest: compounds 3, 1, 2 and 4 (each within the scatter of the next, the first and the last beyond it).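

In this assay, the change on the thiocarbonyl carbon gives no change at the digits printed from compound 2 to compound 4 (within the scatter). Among the compounds shown here, this is the first single-place step that tests the amine ring itself, and it shows that, for this pair, a five-membered ring without sulfur can stand in place of the six-membered ring with sulfur with no shift beyond the scatter. No measurement shown here explains this result.

Because ring size and the ring sulfur change together in this step, the two cannot be told apart. As far as these compounds go, it also remains open whether morpholin-4-yl, piperazin-1-yl or an open-chain dimethylamino group on the same carbon would fit this picture, and whether pyrrolidin-1-yl would do the same with methyl on the aromatic carbon.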